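The source may hold more compounds than are shown below. What is called first, only, known or untested is meant among the compounds shown, and "the series" means these compounds.

Working notes on the series. The shared core is that of compound 1 `O=C1N=C(C2C(=O)c3ccccc3C2=O)CC(c2ccc(Cl)cc2)N1`, which in a functional assay on the whole organism for inhibition, with Rattus norvegicus as the target, read by paw edema, with stated times of 30 min and 3 h, at a dose of 10 mg/kg by the oral route (a higher number here means more inhibition at the dose given (going by the name of the read-out), a lower number less inhibition), gives 31%. Compound 2 `CN(C)c1ccc(C2CC(C3C(=O)c4ccccc4C3=O)=NC(=O)N2)cc1` carries dimethylamino in place of chloro on an aromatic carbon, and in this assay compound 2 gives 20%; the step is a number 11 percentage points lower from compound 1 to compound 2 (beyond the scatter). Among the compounds with values here, on the two numbers so far compound 2 stands lowest, with compound 1 the nearer and higher of the pair.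

Compound 3 `O=C1N=C(C2C(=O)c3ccccc3C2=O)CC(c2ccccc2O)N1` is not yet measured. Against compound 2 the change is 2-hydroxyphenyl in place of 4-(dimethylamino)phenyl on a saturated ring carbon. Within the data shown here, the only measured step, from compound 1 to compound 2, also exchanges the group on the aromatic ring and was modest; it is the one step that bears on the present change, though the group entering here, 2-hydroxyphenyl, is not the one it tested. A step of similar modest size is therefore expected in this assay, with no firm direction. The estimate for compound 3 in this assay is 28%, within 12% to 45%. The expected step is a number 8 percentage points higher from compound 2 to compound 3 (within the scatter).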

Compound 3, a percentage reported as inhibition, in the whole organism at one dose (the size of the read-out at that dose, not a potency): 19%
Compound 3: middle estimate off by 9 percentage points, on the high side; the range from low to high includes it.
By their numbers in this assay, from the lowest: compounds 3 and 2 (each within the scatter of the next); then compound 1.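

In this assay the change from 4-(dimethylamino)phenyl to 2-hydroxyphenyl on the saturated ring carbon gives a number 1 percentage points lower from compound 2 to compound 3 (within the scatter), so these two groups cannot be told apart here, even though one brings a nitrogen substituent and the other a hydroxyl with a hydrogen-bond donor. Measured against 4-chlorophenyl, the same entering group gives a number 12 percentage points lower from compound 1 to compound 3 (beyond the scatter), which is close in size to a number 11 percentage points lower from compound 1 to compound 2 (beyond the scatter); among the three compounds, both groups that replace 4-chlorophenyl therefore give lower numbers than compound 1, and neither goes against this. No measurement to hand accounts for the higher number with 4-chlorophenyl or for the agreement of the other two groups.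

Compound 3 changes both the substituent and its place on the aromatic ring relative to compound 1, so 4-hydroxyphenyl would be needed to separate those two changes. On these data alone, it also remains open whether unsubstituted phenyl, 4-bromophenyl or 4-methoxyphenyl would fall with compound 1 or with compound 2 and compound 3, and so whether the chloro substituent is what sets compound 1 apart.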